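The source may report more compounds than this note shows. Statements on the series, on what has been measured and on what is new or still open speak of the compounds shown alone.

Compound 1 `COC(=O)C1=C(C)N=C(C)/C(=C(/O)OC)C1c1cccc(OCc2no[n+]([O-])c2C)c1` gives 500 nM in a functional assay (aorta) with Rattus norvegicus as the target, in the presence of a further agent that is not named here; a higher number here means that more compound is needed for the effect, a lower number that less compound is needed.
Compound 2 `COC(=O)C1=C(C)N=C(C)/C(=C(/O)OC)C1c1cccc(OCc2nonc2C(N)=O)c1` gives 3500 nM in this assay.
Compound 3 `COC(=O)C1=C(C)N=C(C)/C(=C(/O)OC)C1c1ccccc1OCc1no[n+]([O-])c1C` gives 43 nM in this assay.

Compound 1 and compound 2 share a core and differ by a group of 8 heavy atoms (3 carbon, 3 nitrogen, 2 oxygen; one five-membered aromatic ring with 3 hetero atoms) in place of a group of 7 heavy atoms (3 carbon, 2 nitrogen, 2 oxygen; one five-membered aromatic ring with 3 hetero atoms), on a saturated chain carbon bound to an oxygen on an aromatic ring; this change gave a 7.0-fold higher number from compound 1 to compound 2 (0.85 log units; beyond the scatter). Compound 3 has the same atoms as compound 1, joined differently; the difference between the two cores is not broken down here. Compound 3 stands lowest of the three in this assay. Compound 4 `COC(=O)C1=C(C)N=C(C)/C(=C(/O)OC)C1c1ccccc1OCc1nonc1C(N)=O` is not yet measured. It differs from compound 3 by a group of 8 heavy atoms (3 carbon, 3 nitrogen, 2 oxygen; one five-membered aromatic ring with 3 hetero atoms) in place of a group of 7 heavy atoms (3 carbon, 2 nitrogen, 2 oxygen; one five-membered aromatic ring with 3 hetero atoms), on a saturated chain carbon bound to an oxygen on an aromatic ring, the same change, at the same place, as that made from compound 1 to compound 2. Beside the measured step of a 7.0-fold higher number from compound 1 to compound 2 (0.85 log units; beyond the scatter), the expected step here is a 7.0-fold higher number from compound 3 to compound 4 (0.84 log units; beyond the scatter). Going by the values given here, that expectation rests only on the single measured pair, a 7.0-fold higher number from compound 1 to compound 2 (0.85 log units; beyond the scatter). Compound 4 is therefore estimated at 300 nM in this assay, with a likely range from 100 nM to 900 nM.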

Compound 4, half-maximal effective concentration: 970 nM
For compound 4 the middle estimate is 3.2-fold (0.51 log units) below the measured one; the whole stated range lies below it.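

Setting 4-carbamoyl-1,2,5-oxadiazol-3-yl in place of the group on the saturated chain carbon bound to an oxygen on an aromatic ring gave a 23-fold higher number from compound 3 to compound 4 (1.35 log units; beyond the scatter) in this assay. The direction of the change therefore held on both cores, but its size did not carry over: the same change on two cores in this assay, a 7.0-fold higher number (0.85 log units; beyond the scatter) from compound 1 to compound 2 and a 23-fold higher number (1.35 log units; beyond the scatter) from compound 3 to compound 4, 3.2-fold (0.51 log units) apart, beyond the scatter of two such steps. Going by these compounds alone, with only two pairs, this does not show how large the step would be on any further core, nor why the two steps differ.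

The compounds shown leave open how a carboxylic acid or a nitrile in place of the carbamoyl group would stand in this assay. They also leave open whether the higher number would recur on a third core.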